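The source may hold more compounds than are shown below. What is called first, only, known or untested is meant among the compounds shown, and "the series" means these compounds.

Going by the values given here, in an ADME assay on microsomes from liver (Mus musculus) for metabolic stability (a higher number here means that the compound lasts longer, a lower number that the compound disappears faster), compound 1 (`COC[C@H](NC(=O)[C@H](CSC)NC(=O)c1cc(C)on1)C(=O)N[C@@H](CC(C)C)C(=O)[C@@]1(C)CO1`) gives 0.195 h and compound 2 (`CSC[C@H](NC(=O)c1cc(C)on1)C(=O)N[C@@H](CSC)C(=O)N[C@@H](CC(C)C)C(=O)[C@@]1(C)CO1`) gives 0.085 h as the lowest of the two numbers so far. Among the compounds with values here, the only measured step (a 2.3-fold lower number from compound 1 to compound 2 (0.36 log units; beyond the scatter)) is modest but beyond the scatter, and it lies on a saturated chain carbon, not at the place changed now. Compound 3 (`CSC[C@H](NC(=O)c1cnc(C)s1)C(=O)N[C@@H](CSC)C(=O)N[C@@H](CC(C)C)C(=O)[C@@]1(C)CO1`) carries 2-methyl-1,3-thiazol-5-yl in place of 5-methyl-1,2-oxazol-3-yl on a carbonyl carbon and keeps the rest of compound 2. Within the data shown here, no measured step covers this exchange, so no step beyond the scatter is expected in this assay and no direction is favoured. The expected step (a 1.1-fold higher number from compound 2 to compound 3 (0.02 log units; within the scatter)) is small. Compound 3 is estimated at 0.09 h (range 0.04 h to 0.18 h) for now.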

Compound 3, half-life: 0.165 h
Compound 3: middle estimate off by 1.8-fold (0.26 log units), on the low side, within the range that was stated.
By their numbers in this assay, from the lowest: compounds 2, 3 and 1 (each within the scatter of the next, the first and the last beyond it).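

In this assay, going by these compounds alone, the first reading at this carbonyl carbon, 2-methyl-1,3-thiazol-5-yl in place of 5-methyl-1,2-oxazol-3-yl, gives a 1.9-fold higher number from compound 2 to compound 3 (0.29 log units; within the scatter), so this exchange does not separate the two rings in this assay. The earlier step covered only a saturated chain carbon, so this position now has its own reading. No available data bear on the result. As far as these compounds go, whether a phenyl or pyridin-3-yl ring on this carbonyl carbon would read differently remains open, as does whether the same exchange reads alike with the methoxy chain of compound 1.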